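A few compounds are considered here, and "the series" means these few. Any claim that something is new, unique, unknown or untested is made for them only; others in the source may bear on it.

Three compounds share one core and differ only in a single group on a six-membered aromatic ring of carbon only. Compound 1 `COc1cc(-n2ncnc2-c2cccc(F)c2)cc(OC)c1OC` carries a fluoro there, compound 2 `COc1cc(-n2ncnc2-c2ccccc2)cc(OC)c1OC` a hydrogen, and compound 3 `COc1cc(-n2ncnc2-c2cccc(Cl)c2)cc(OC)c1OC` a chloro. In a functional assay on A549 cells (Homo sapiens) for antiproliferative activity, read by MTT assay, with a stated time of 72 h (on this read-out lower numbers stand for stronger inhibition and higher numbers for weaker inhibition), compound 1 gives > 10000 nM, which is a limit of the assay and not a number. In this assay compound 2 likewise gives only the limit > 10000 nM. In this assay compound 3 also stops at the limit > 10000 nM. Because all three values sit at the limit of > 10000 nM in this assay, at which 3 of the 3 values shown sit, the steps a step that the two limits leave unreadable from compound 1 to compound 2, a step that the two limits leave unreadable from compound 1 to compound 3 and a step that the two limits leave unreadable from compound 2 to compound 3 cannot be read, so compound 3 stands at the limit with nothing shown to set it apart from the other two. Compound 4 `CCOc1cccc(-c2ncnn2-c2cc(OC)c(OC)c(OC)c2)c1` differs from compound 3 in one place: ethoxy in place of chloro on an aromatic carbon. Among the measured compounds shown here, no measured step shows what an ethoxy does on this ring, so the expected step of an at least 1.1-fold lower number from compound 3 to compound 4 (0.04 log units; that floor lies within the scatter) is set close to no change, with the limit itself the likeliest outcome. Compound 4 is therefore estimated at 9000 nM in this assay, within a range from 1500 nM to 30000 nM.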

Compound 4, half-maximal inhibitory concentration: > 10000 nM
Compound 4: no number, only a limit (the forecaster's own chance of this, stated with the estimate: 60%); middle value at least 1.1-fold (0.04 log units) away from the limit.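

In this assay compound 4 gives > 10000 nM as a limit of the assay and not a number. Its steps from compound 1, compound 2 and compound 3 cannot be read, because all four values stop at one point: the limit of > 10000 nM in this assay, at which 4 of the 4 values shown sit. The compounds shown leave open how strongly any of them acts, and whether changing this group alters the activity at all.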